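The source may hold more compounds than are shown below. What is called first, only, known or untested is meant among the compounds shown, and "the series" means these compounds.

Working notes on the series.

Compound 1 `COc1ccc2c(c1)NC(=O)CN2c1nc(OCC2CC2)nc2ccccc12` gives 15.8 nM in a functional assay on A549 cells (Homo sapiens) for inhibition, read by sulforhodamine B assay, with a stated time of 48 h; on this read-out higher numbers stand for weaker inhibition of growth and lower numbers for stronger inhibition of growth. Compound 2 `COc1ccc2c(c1)NC(=O)CN2c1nc(Nc2cccc(C#N)c2)nc2ccccc12` gives 75.4 nM, the highest of the three numbers recorded: compound 1 stands nearest, a step of a 4.8-fold higher number from compound 1 to compound 2 (0.68 log units; beyond the scatter) away, and compound 3 `COc1ccc2c(c1)NC(=O)CN2c1nc(NC2CC2)nc2ccccc12` stands furthest with 1.12 nM. The two measured steps from compound 1 read a 4.8-fold higher number from compound 1 to compound 2 (0.68 log units; beyond the scatter) and a 14-fold lower number from compound 1 to compound 3 (1.15 log units; beyond the scatter); between the two amines the step is a 67-fold lower number from compound 2 to compound 3 (1.83 log units; beyond the scatter).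

Compound 4 `COc1ccc2c(c1)NC(=O)CN2c1nc(NC2CCCC2)nc2ccccc12` is not yet measured. It differs from compound 2 in one place: cyclopentyl in place of 3-cyanophenyl on a nitrogen on an aromatic ring. Within the data shown here, the step that bears most directly on this is the one from compound 2 to compound 3, where a cyclopropyl on the same nitrogen in place of the 3-cyanophenyl gave a 67-fold lower number from compound 2 to compound 3 (1.83 log units; beyond the scatter); the step from compound 1 to compound 3 likewise shows that a small saturated ring on that nitrogen sits at the low end of the numbers, at a 14-fold lower number from compound 1 to compound 3 (1.15 log units; beyond the scatter). A cyclopentyl is another saturated carbon ring, though larger than the cyclopropyl, so a large downward step in this assay is expected for compound 4, plausibly somewhat short of that seen for compound 3. The expected step from compound 2 is a 25-fold lower number from compound 2 to compound 4 (1.40 log units; beyond the scatter). The estimate for compound 4 is 3 nM, with a range from 0.8 nM to 12 nM.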

Compound 4, concentration for 50% growth inhibition: 7.67 nM
The estimate for compound 4 lay 2.6-fold (0.41 log units) below the measured number; measured number inside the range.
By their numbers in this assay, from the lowest: compound 3; then compound 4; then compound 1; then compound 2.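

With a second saturated ring on this nitrogen, this assay again gives a downward step, a 9.8-fold lower number from compound 2 to compound 4 (0.99 log units; beyond the scatter), so the fall from the 3-cyanophenyl compound is not confined to cyclopropyl. Ring size on that nitrogen also counts, at a 6.8-fold higher number from compound 3 to compound 4 (0.84 log units; beyond the scatter), which leaves compound 3 with the lowest number of the four and shows that the saturated rings are not interchangeable here. Against the cyclopropylmethoxy compound, the cyclopentylamino group gives only a 2.1-fold lower number from compound 1 to compound 4 (0.31 log units; beyond the scatter), a much smaller step than a 14-fold lower number from compound 1 to compound 3 (1.15 log units; beyond the scatter), so an amine nitrogen carrying a saturated ring does not in itself deliver the full drop seen with cyclopropylamino.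

Among these compounds, with only two saturated rings in view, it remains open whether the number climbs steadily with ring size; a cyclobutyl or cyclohexyl on the same nitrogen, or an open chain such as isopropyl, would test this. The data at hand offer no measurement that accounts for any of these steps.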